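Working notes: from compound 1 to compound 3

A few compounds are considered here, and "the series" means these few. Any claim that something is new, unique, unknown or untested is made for them only; others in the source may bear on it.

- compound 1 `CCc1ccc(NC(=O)Nc2cc(C)nc3ccccc23)cc1`: 16000 nM
- compound 2 `Cc1cc(NC(=O)Nc2ccccc2C(C)(C)C)c2ccccc2n1`: > 25000 nM (a limit)

Among the compounds with values here, in an ADME assay on HEK293 cells (Homo sapiens) for cytotoxicity, with a stated time of 72 h (a higher number here means that more compound is needed for the effect, a lower number that less compound is needed), compound 1 gives 16000 nM, the only actual number so far. Compound 2 is reported only as a limit, > 25000 nM.

Compound 3 `COC(=O)c1ccc(NC(=O)Nc2cc(C)nc3ccccc23)cc1` keeps the core of compound 1 and differs in one place: methoxycarbonyl in place of ethyl on an aromatic carbon. Methoxycarbonyl stands in place of ethyl on an aromatic carbon, para to a large group.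

Within the data shown here, no pair of measured compounds differing in one place is available, so this change has no direct precedent in this assay. The expectation is therefore cautious, with no step beyond the scatter in either direction. The estimated change, a 1.1-fold higher number from compound 1 to compound 3 (0.05 log units; within the scatter), is not expected to pass the scatter. For compound 3 the expected value is 18000 nM, with an estimated range of 8000 nM to 30000 nM.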

Compound 3, half-maximal effective concentration: 15000 nM
For compound 3 the middle estimate is 1.2-fold (0.08 log units) above the measured one, and the stated range covers the measured number.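

Within the data shown here, with a 1.1-fold lower number from compound 1 to compound 3 (0.03 log units; within the scatter) as the first readable step in this assay, the series now shows that on this aromatic carbon, para to a large group, methoxycarbonyl can stand in place of ethyl without a change beyond the scatter. The entering group brings a double bond outside aromatic rings and hydrogen-bond acceptors that ethyl does not have, yet this assay does not separate the two compounds. No measurement shown gives a reason for this result.

As far as these compounds go, whether a carboxylic acid, an amine or a longer chain on this same carbon would move the number beyond the scatter remains open. Among these compounds, the value of compound 2, > 25000 nM, is a limit and not a number, and no step in one place leads to it.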